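The source may hold more compounds than are shown below. What is called first, only, known or untested is meant among the compounds shown, and "the series" means these compounds.

Measured so far in an ADME assay on Vero cells (Chlorocebus sabaeus) for cytotoxicity, read by MTT assay, with a stated time of 96 h; a higher number here means that more compound is tolerated, a lower number that less compound is tolerated:
- compound 1, `COc1ccc(-c2nc3cc(/C(C)=N/NC(N)=O)ccc3[nH]2)c(OC)c1`: 80000 nM
- compound 2, `COc1ccc(-c2nc3cc(/C(C)=N/NC(N)=O)ccc3n2C2CCCCC2)c(OC)c1`: 20000 nM
- compound 3, `C/C(=N\NC(N)=S)c1ccc2c(c1)nc(-c1ccoc1)n2C1CCCCC1`: 25000 nM

Compound 1 and compound 2 share a core and differ in one place: hydrogen in place of cyclohexyl on an aromatic nitrogen. That change gave a 4.0-fold higher number from compound 2 to compound 1 (0.60 log units; beyond the scatter). Compound 3 stands on a different core, and the difference between the two cores is not broken down here. Compound 4, `C/C(=N\NC(N)=S)c1ccc2[nH]c(-c3ccoc3)nc2c1`, has not yet been measured in this assay. It differs from compound 3 by hydrogen in place of cyclohexyl on an aromatic nitrogen. For the measured compounds named here, this is the same kind of change as the one from compound 2 to compound 1, though the surroundings differ: in compound 3 the ring atom beside the aromatic nitrogen bears a furan-3-yl group, while in compound 2 it bears a 2,4-dimethoxyphenyl group. Since the earlier change gave a 4.0-fold higher number from compound 2 to compound 1 (0.60 log units; beyond the scatter), a step of similar size is expected here, that is a 4.0-fold higher number from compound 3 to compound 4 (0.60 log units; beyond the scatter). Compound 4 is therefore expected to give about 100000 nM in this assay, most likely between 40000 nM and 250000 nM.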

Compound 4, half-maximal cytotoxic concentration: 100000 nM
Beside the measured number, compound 4's estimate shows no gap at the digits printed; measured number inside the range.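

In this assay, putting hydrogen in place of cyclohexyl on the aromatic nitrogen gave a 4.0-fold higher number from compound 3 to compound 4 (0.60 log units; beyond the scatter). Set beside the earlier case, the change carried from one core to the other at the same size: the same change on two cores in this assay, a 4.0-fold higher number (0.60 log units; beyond the scatter) from compound 2 to compound 1 and a 4.0-fold higher number (0.60 log units; beyond the scatter) from compound 3 to compound 4, 1.0-fold (0.00 log units) apart, within the scatter of two such steps. For the compounds shown here, these are only two pairs, and their cores differ in more than one place, including the furan-3-yl and 2,4-dimethoxyphenyl groups, so the result shows that the step held on these two cores, but it does not show that it would hold on every core or explain why it occurs.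

On this nitrogen, the compounds shown carry only cyclohexyl or hydrogen, leaving open how the number behaves with other groups there. A small methyl, a longer chain, or a chain ending in an amine or a carboxylic acid could show whether the number changes gradually or only when cyclohexyl is removed altogether.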